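Aryl swap on the shared core: compound 3 to compound 4

A few compounds are considered here, and "the series" means these few. Any claim that something is new, unique, unknown or untested is made for them only; others in the source may bear on it.

Values so far in a functional assay on KBVIN cells (Homo sapiens) for antiproliferative activity, read by sulforhodamine B assay, with a stated time of 3 days (on this read-out lower numbers stand for an effect already at smaller amounts and higher numbers for an effect only at larger amounts of compound), are these.
- compound 1 `CCC1=C(O)c2c(oc(-c3ccc(SC)cc3)cc2=O)C(CC)(CC)C1=O` gives 1.38 uM
- compound 2 `CCC1=C(O)c2c(oc(-c3ccc(C)cc3C)cc2=O)C(CC)(CC)C1=O` gives 8.52 uM
- compound 3 `CCC1=C(O)c2c(oc(-c3cc(C)c(C)cc3C)cc2=O)C(CC)(CC)C1=O` gives 4.37 uM

Compound 3 sits with compound 2, since a 1.9-fold lower number from compound 2 to compound 3 (0.29 log units; within the scatter) stays within the scatter, so that added methyl separates nothing. Both lie clearly above compound 1, with a 6.2-fold higher number from compound 1 to compound 2 (0.79 log units; beyond the scatter) and a 3.2-fold higher number from compound 1 to compound 3 (0.50 log units; beyond the scatter) as the measured gaps.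

The next analogue is compound 4 `CCC1=C(O)c2c(oc(-c3ccc(OC)c(C)c3)cc2=O)C(CC)(CC)C1=O` with 4-methoxy-3-methylphenyl in place of 2,4,5-trimethylphenyl on an aromatic carbon and the rest of the core unchanged. Going by the values given here, no measured compound carries a methoxy group, so the data offer no direct step for it. Among the compounds with values here, the closest guide is the pair of modest steps from compound 1, the only member here whose aryl group is not purely methyl-substituted. Going by these compounds, on that thin basis, a small move from compound 3 toward compound 1 seems more likely than a move away, though a result near compound 3 remains open.

The estimated step in this assay is a 1.7-fold lower number from compound 3 to compound 4 (0.24 log units; within the scatter) and is thus expected to stay inside the scatter. The value expected for compound 4 is 2.5 uM (estimated range 0.9 uM to 7 uM).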

Compound 4, concentration for half-maximal effect: 0.1 uM
Estimate against measurement, compound 4: 25-fold (1.40 log units) above; the measured number lies below the stated range.
By their numbers in this assay, from the lowest: compound 4; then compound 1; then compounds 3 and 2 (each within the scatter of the next).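

Going by these compounds alone, at the aromatic carbon next to the ring oxygen, the aryl group alone can move the result in this assay much further than the earlier compounds showed: 4-methoxy-3-methylphenyl gives a 44-fold lower number from compound 3 to compound 4 (1.64 log units; beyond the scatter), an 85-fold lower number from compound 2 to compound 4 (1.93 log units; beyond the scatter) and a 14-fold lower number from compound 1 to compound 4 (1.14 log units; beyond the scatter). All three steps are large and beyond the scatter, so compound 4 stands clearly apart from compound 1 as well as from the purely methyl-substituted aryl groups of compound 2 and compound 3, a separation far wider than any seen among those three. The heavy-atom count is the same in the groups that leave and enter between compound 3 and compound 4, so the size of the step does not follow that count, and nothing measured here bears on why the step is so large.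

Within 4-methoxy-3-methylphenyl, the methoxy group and the methyl group enter together, and the compounds shown do not separate the share of either. Going by these compounds, how an ethoxy group, a hydroxyl or an amine would read in place of that methoxy group also stays open.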